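The source may report more compounds than this note shows. Statements on the series, on what has been measured and on what is new or still open speak of the compounds shown alone.

Measured so far in a functional assay on DLD-1 cells (Homo sapiens) for antiproliferative activity, read by CellTiter-Glo, with a stated time of 72 h; a higher number here means a weaker inhibitor, a lower number a stronger inhibitor:
compound 1, `Cc1cc(C)c(S(=O)(=O)N2CCC(N3CCN(C)CC3)CC2)c(C)c1`, 1100 nM
compound 2, `Cc1cc(C)c(S(=O)(=O)N2CCC(N3CCC(Cc4ccc(F)cc4)CC3)CC2)c(C)c1`, 18 nM

Among the measured compounds shown here, compound 2 gives the lowest number of the two; the only other number, that of compound 1, is higher by more than the scatter allows. Compound 3, `Cc1cc(C)c(S(=O)(=O)N2CCC(N3CCC(C(C)C)CC3)CC2)c(C)c1`, is not yet measured. It differs from compound 2 in one place: isopropyl in place of 4-fluorobenzyl on a saturated ring carbon. For the measured compounds named here, no measured pair shows what this change does here. For compound 3 the step expected in this assay, an 11-fold higher number from compound 2 to compound 3 (1.05 log units; beyond the scatter), is toward a weaker inhibitor, beyond the scatter. The estimate for compound 3 is 200 nM, within 50 nM to 800 nM.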

Compound 3, half-maximal inhibitory concentration: 0.3 nM
The estimate for compound 3 lay 670-fold (2.82 log units) above the measured number; measured number outside the range, below it.
By their numbers in this assay, from the lowest: compound 3; then compound 2; then compound 1.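

In this assay the group on the saturated ring carbon need not carry an aromatic ring: isopropyl in place of 4-fluorobenzyl gives a 60-fold lower number from compound 2 to compound 3 (1.78 log units; beyond the scatter) and the smaller group is the better one in this pair. The change of 4-methylpiperazin-1-yl to 4-isopropylpiperidin-1-yl gives a 3700-fold lower number from compound 1 to compound 3 (3.56 log units; beyond the scatter) in the same assay. Nothing measured here accounts for the size of either step.

Open, on these data alone, is whether methyl, cyclopropyl or tert-butyl at this carbon would match isopropyl. Also open, as far as these compounds go, is whether a longer chain such as n-butyl would keep this level.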